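The compounds below may be only part of what the source reports. "The series", "measured", "known", "first", "only" and "open" are said of these compounds alone.

The three measured compounds share one core and differ only in the aryl group that caps the amide-type nitrogen at one end. Compound 1 `O=C(Nc1cccc(-n2cc(-c3ccncc3)c(-c3ccc(Cl)c(O)c3)n2)c1)Nc1cccc(C(F)(F)F)c1` gives 3310 nM in a functional assay on Hs-578T cells (Homo sapiens) for inhibition, read by sulforhodamine B assay, with a stated time of 48 h (on this read-out lower numbers stand for stronger inhibition of growth and higher numbers for weaker inhibition of growth), the highest of the three numbers. Compound 2 `COc1cc(-c2nn(-c3cccc(NC(=O)c4cccc(C(F)(F)F)c4)c3)cc2-c2ccncc2)ccc1Cl` gives 1070 nM in this assay, and compound 3 `O=C(Nc1cccc(-n2cc(-c3ccncc3)c(-c3ccc(Cl)c(O)c3)n2)c1)Nc1ccc(Cl)c(Cl)c1` gives 785 nM. Among the compounds with values here, the one step that can be traced to a single change is a 4.2-fold lower number from compound 1 to compound 3 (0.62 log units; beyond the scatter).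

Compound 4 `O=C(Nc1cccc(-n2cc(-c3ccncc3)c(-c3ccc(Cl)c(O)c3)n2)c1)Nc1cc(C(F)(F)F)cc(C(F)(F)F)c1` is not yet measured. It differs from compound 1 in one place: trifluoromethyl in place of hydrogen on an aromatic carbon. The measured step that bears on this is the change from compound 1 to compound 3, which lowered the number beyond the scatter, and compound 2, which differs from compound 1 in more than one place, also sits well below compound 1. Both shifts point the same way, yet neither is the same change as adding a second trifluoromethyl group to the cap, so only a modest step in that direction is expected, with wide uncertainty. For compound 4 the estimated value in this assay is 1500 nM, with a range from 500 nM to 5000 nM. That estimate means an expected step of a 2.2-fold lower number from compound 1 to compound 4 (0.34 log units; beyond the scatter).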

Compound 4, concentration for 50% growth inhibition: 1140 nM
Compound 4: the middle estimate sits 1.3-fold (0.12 log units) above what was measured; low and high end bracket the measured number.
By their numbers in this assay, from the lowest: compounds 3, 2 and 4 (each within the scatter of the next); then compound 1.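

In this assay, placing a second trifluoromethyl group on the cap of compound 1 gives a 2.9-fold lower number from compound 1 to compound 4 (0.46 log units; beyond the scatter), which shows that this aromatic carbon, meta to a trifluoromethyl group, can carry a substituent and that growth inhibition here becomes stronger rather than weaker. The earlier single change, a 4.2-fold lower number from compound 1 to compound 3 (0.62 log units; beyond the scatter), swapped one substituted cap for another, whereas this step keeps the existing trifluoromethyl group and replaces a single hydrogen, so the shift in the number can be tied to one spot on the ring. The data shown offer no measurement that explains why the number falls.

From the compounds shown here alone, it remains open whether this shift belongs to trifluoromethyl itself or whether other groups on the same carbon, such as a methyl group, an amine or a carboxylic acid, would move the number in the same direction, by a similar amount, or the opposite way. Going by these compounds, it also remains open whether adding the same group would lower the number on another cap, such as the 3,4-dichlorophenyl of compound 3.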